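The compounds below may be only part of what the source reports. "The series", "measured", "known", "first", "only" and "open" are said of these compounds alone.

Measured so far in a functional assay on HeLa cells for agonist activity at 5-hydroxytryptamine receptor 6 (Homo sapiens), read by cAMP accumulation and immunoassay; a lower number here means a smaller maximal response, a higher number a larger maximal response:
compound 1 `CN1CCC(n2cc(S(=O)(=O)c3cccc(F)c3)c3cccnc32)C1` gives 54%
compound 2 `O=S(=O)(c1ccccc1)c1cn(C2CCCNC2)c2ncccc12` gives 56%
compound 3 `O=S(=O)(c1ccccc1Cl)c1cn(C2CCCNC2)c2ncccc12` gives 84%

Compound 3 stands highest of the three numbers; the nearest is compound 2, and the furthest is compound 1, both of them lower by more than the scatter. For the measured compounds named here, the one single-point step among the measured compounds, a number 28 percentage points higher from compound 2 to compound 3 (beyond the scatter), is the change that bears on the next compound: a chloro on an aromatic carbon raised the maximal response by a modest amount.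

Compound 4 `O=S(=O)(c1cccc(Cl)c1)c1cn(C2CCCNC2)c2ncccc12` differs from compound 3 as follows: 3-chlorophenyl in place of 2-chlorophenyl on a sulfonyl sulfur. The chloro is kept but moved, so the step from compound 2 to compound 3 speaks only indirectly. Compound 1 carries a 3-fluorophenyl on the sulfonyl sulfur, yet with a different amine, so its value of 54% only hints that a substituent in that position need not lift the response as the 2-chloro did. Compound 4 is therefore expected to fall back toward compound 2, with an estimated step of a number 19 percentage points lower from compound 3 to compound 4 (beyond the scatter). The estimate for compound 4 in this assay is 65%, between 45% and 88%.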

Compound 4, largest response reached (Emax), in percent of the reference or control that the assay uses: 49%
Compound 4: the middle estimate sits 16 percentage points above what was measured, within the range that was stated.
By their numbers in this assay, from the lowest: compounds 4, 1 and 2 (each within the scatter of the next); then compound 3.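

In this assay the step of a number 35 percentage points lower from compound 3 to compound 4 (beyond the scatter) shows that moving the chloro on the ring attached to the sulfonyl sulfur matters as much as adding it did. Beside the plain phenyl, the 3-chlorophenyl gives a number 7 percentage points lower from compound 2 to compound 4 (within the scatter) and so cannot be told apart from it, which leaves 2-chlorophenyl as the only group among these compounds with a raised maximal response. Nothing measured here accounts for the difference between the two chlorophenyl groups.

As far as these compounds go, whether the raised response needs chloro itself remains open, since a bromo or methoxy group in the place held by the chloro of 2-chlorophenyl could answer that. From the compounds shown here alone, it is also open whether the gap between the two chlorophenyl groups would persist with the amine of compound 1 on the shared core.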